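Replacing cyclopentyl by isobutyl on the ester oxygen

This account rests on a few compounds, and the source may have more. Where it says the series, first, only, none or still open, it means among the compounds named here.

Compound 1 `CC1=NC(C)=C([N+](=O)[O-])C(c2cccnc2)/C1=C(\O)OC1CCCCC1`: 2760 nM
Compound 2 `CC1=NC(C)=C([N+](=O)[O-])C(c2cccnc2)/C1=C(\O)OC1CCCC1`: 3280 nM

In a functional assay (cardiac atrium) for agonist activity, with Cavia porcellus as the target (a higher number here means that more compound is needed for the effect, a lower number that less compound is needed), compound 2 gives 3280 nM. Going by the values given here, its only measured neighbour is compound 1, and the step of a 1.2-fold higher number from compound 1 to compound 2 (0.07 log units; within the scatter) lies within the scatter, so the two cannot be told apart. Compound 3 `CC1=NC(C)=C([N+](=O)[O-])C(c2cccnc2)/C1=C(\O)OCC(C)C` differs from compound 2 by isobutyl in place of cyclopentyl on an oxygen on an unsaturated carbon. Among the compounds with values here, the one step that bears on this place, a 1.2-fold higher number from compound 1 to compound 2 (0.07 log units; within the scatter), was small, so for compound 3 a step of a 1.0-fold higher number from compound 2 to compound 3 (0.00 log units; within the scatter) is expected, that is none beyond the scatter. Compound 3 is estimated at 3300 nM, with a range from 1200 nM to 9000 nM.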

Compound 3, half-maximal effective concentration: 1740 nM
Compound 3: middle estimate off by 1.9-fold (0.28 log units), on the high side, and the stated range covers the measured number.
By their numbers in this assay, from the lowest: compounds 3, 1 and 2 (each within the scatter of the next).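

In this assay the isobutyl group, which has no ring, gives a step of a 1.9-fold lower number from compound 2 to compound 3 (0.28 log units; within the scatter) against cyclopentyl and a step of a 1.6-fold lower number from compound 1 to compound 3 (0.20 log units; within the scatter) against cyclohexyl. Neither step goes beyond the scatter, so compound 1, compound 2 and compound 3 cannot be told apart, and at this place on the oxygen a branched chain reads the same as either carbon ring. No evidence is available that bears on this result. The compounds shown leave open whether a much longer chain, an amine or a carboxylic acid at this place would shift the number beyond the scatter.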